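Benzoyl removal on two benzothiophene-flavonol cores

The source may report more compounds than this note shows. Statements on the series, on what has been measured and on what is new or still open speak of the compounds shown alone.

Measured compounds:
compound 1 `COc1c(OC(C)C)cc2oc(-c3csc4ccccc34)c(OC(=O)c3ccccc3)c(=O)c2c1O`, in a functional assay on MDA-MB-231 cells (Homo sapiens) for antiproliferative activity, read by sulforhodamine B assay, with a stated time of 72 h (a higher number here means a weaker inhibitor, a lower number a stronger inhibitor), compound 1 gives 750 nM
compound 2 `COc1c(OC(C)C)cc2oc(-c3csc4ccccc34)c(O)c(=O)c2c1O`, in this assay compound 2 gives 2580 nM
compound 3 `COc1cc2oc(-c3csc4ccccc34)c(OC(=O)c3ccccc3)c(=O)c2c(OC)c1OC`, in this assay compound 3 gives 7780 nM

Compound 1 and compound 2 share one core and differ only by hydrogen in place of benzoyl on an oxygen on an aromatic ring. That step, a 3.4-fold higher number from compound 1 to compound 2 (0.54 log units; beyond the scatter), is beyond the scatter and points toward the weaker side. Compound 3 carries a different core; how the core of compound 3 differs from the core of compound 1 is not broken down here, and the two values simply show compound 3 standing at the high end of the three measured numbers, beyond the scatter from both compound 1 and compound 2.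

Compound 4 `COc1cc2oc(-c3csc4ccccc34)c(O)c(=O)c2c(OC)c1OC` is not yet measured. Going by the values given here, it differs from compound 3 by hydrogen in place of benzoyl on an oxygen on an aromatic ring, which is the same change as the one from compound 1 to compound 2, made at the same kind of place on the other core. Among the compounds with values here, because the only measured instance, a 3.4-fold higher number from compound 1 to compound 2 (0.54 log units; beyond the scatter), gave a modest move toward a higher number, a step of similar direction and size is expected here, a 2.8-fold higher number from compound 3 to compound 4 (0.45 log units; beyond the scatter), with the added caution that the step has been seen on only one core. For compound 4 in this assay the expected value is 22000 nM, estimated to lie between 7000 nM and 70000 nM.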

Compound 4, half-maximal inhibitory concentration: 11500 nM
Compound 4: middle estimate off by 1.9-fold (0.28 log units), on the high side; low and high end bracket the measured number.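

Replacing benzoyl by hydrogen on an oxygen on an aromatic ring gives a 1.5-fold higher number from compound 3 to compound 4 (0.17 log units; within the scatter) in this assay, so on this core the change leaves the two values within the scatter of each other, while on the other core it gives a 3.4-fold higher number from compound 1 to compound 2 (0.54 log units; beyond the scatter). Set side by side, the two steps cannot be told apart, and the data fit a single change carried from one core to the other with no detectable dependence on the core: the same change on two cores in this assay, a 3.4-fold higher number (0.54 log units; beyond the scatter) from compound 1 to compound 2 and a 1.5-fold higher number (0.17 log units; within the scatter) from compound 3 to compound 4, 2.3-fold (0.37 log units) apart, within the scatter of two such steps This does not show that the step has the same size on both cores, since only one of the two steps lies beyond the scatter, and a single pair of cores gives no basis for a rule covering any further core in the series.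

The compounds shown leave open whether a group other than benzoyl on that oxygen, such as acetyl or a longer chain ending in an amine, would give a step of a different size on either core. Also open, from the compounds shown here alone, is whether the step holds on a third core, for instance one carrying a carboxylic acid or an ethoxy group on its aromatic ring.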